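An Ester Cut Back to the Acid

The source may report more compounds than this note shows. Statements on the series, on what has been measured and on what is new or still open speak of the compounds shown alone.

Compound 1, `CCOC(=O)c1sc(-c2nc3ccccc3n2CC)nc1C`: in a functional assay on SMMC-7721 cells (Homo sapiens) for cytotoxicity, read by MTT assay, with a stated time of 24 h (on this read-out higher numbers stand for weaker inhibition and lower numbers for stronger inhibition), compound 1 gives 9850 nM.
Compound 2, `CCOC(=O)c1sc(-c2nc3ccccc3n2C(C)C)nc1C`: compound 2 reaches only the limit > 20000 nM.
Compound 3, `CCOC(=O)c1sc(-c2nc3ccccc3n2Cc2ccccc2)nc1C`: compound 3 gives 2780 nM.

Among the two compounds with a number, compound 3 stands lowest; its nearest neighbour is compound 1, and the step of a 3.5-fold lower number from compound 1 to compound 3 (0.55 log units; beyond the scatter) lies beyond the scatter. Compound 2 sits at the limit (the limit of > 20000 nM in this assay, at which 1 of the 3 values shown sits), so the step of an at least 2.0-fold higher number from compound 1 to compound 2 (0.30 log units; that floor lies within the scatter) has only a floor, one that lies within the scatter, while the step of an at least 7.1-fold lower number from compound 2 to compound 3 (0.85 log units; beyond the scatter) is at least modest.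

Compound 4, `Cc1nc(-c2nc3ccccc3n2Cc2ccccc2)sc1C(=O)O`, differs from compound 3 by hydrogen in place of ethyl on an oxygen next to a carbonyl group. None of the three measured steps touches this position: each of them changed only the group on the aromatic nitrogen, and the ester stayed fixed throughout. No measured step therefore bears on the change from compound 3 to compound 4, and the direction of the step cannot be read from the data shown. With only compound 3 as an anchor, compound 4 is estimated at 8000 nM, between 1500 nM and 20000 nM, which means an expected step of a 2.9-fold higher number from compound 3 to compound 4 (0.46 log units; beyond the scatter), with a real chance that only a limit is reported.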

Compound 4, half-maximal inhibitory concentration: 15300 nM
For compound 4 the middle estimate is 1.9-fold (0.28 log units) below the measured one; the measured number falls inside the stated range.
By their numbers in this assay, from the lowest: compound 3; then compounds 1 and 4 (each within the scatter of the next). At a limit, above all of these: compound 2.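

Among these compounds, the earlier compounds changed only the group on the aromatic nitrogen, so this is the first sign that the site on an oxygen next to a carbonyl group also moves the read-out in this assay as well: going from ethoxycarbonyl to carboxy, with the benzyl group held fixed, gives a 5.5-fold higher number from compound 3 to compound 4 (0.74 log units; beyond the scatter) and thus a modest weakening of inhibition. The ethyl on this oxygen is therefore no neutral passenger in this pair, and its loss counts for about as much as the modest step seen on the aromatic nitrogen between the ethyl and benzyl compounds. Nothing shown accounts for why the number rises on this change, and no measurement among these compounds bears on it.

The compounds shown carry the carboxy group only alongside benzyl, so it stays open whether the same step would appear with ethyl or isopropyl on the aromatic nitrogen. They also leave open how a methyl ester, a longer chain on this oxygen or a primary amide in place of the ester would read in this assay, and so whether the ethyl itself or the ester as a whole matters.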